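The source may report more compounds than this note shows. Statements on the series, on what has been measured and on what is new or still open speak of the compounds shown alone.

Measured so far:
- compound 1 `C/C=C/C(=O)N(Cc1cccc(O)c1)c1cc(OC)c(OC)c(OC)c1`: 14700 nM
- compound 2 `CCC(=O)N(Cc1ccc(OC)c(O)c1)c1cc(OC)c(OC)c(OC)c1`: 98 nM
- compound 3 `C/C=C/C=C/C(=O)N(Cc1ccc(OC)c(O)c1)c1cc(OC)c(OC)c(OC)c1`: 180 nM

In a functional assay on KYSE-450 cells (Homo sapiens) for inhibition, read by MTT assay, with a stated time of 48 h (on this read-out higher numbers stand for weaker inhibition and lower numbers for stronger inhibition), compound 1 stands at the highest of the three numbers; compound 3 is nearer and compound 2 furthest, both well beyond the scatter from compound 1. Going by the values given here, the only single-site step among the measured compounds, a 1.8-fold higher number from compound 2 to compound 3 (0.26 log units; within the scatter), concerns the carbonyl chain and lies within the scatter; it says nothing about the group on the saturated chain carbon bound to the amide-type nitrogen.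

Compound 4 `C/C=C/C(=O)N(Cc1ccc(OC)c(C)c1)c1cc(OC)c(OC)c(OC)c1` differs from compound 1 by 4-methoxy-3-methylphenyl in place of 3-hydroxyphenyl on a saturated chain carbon bound to an amide-type nitrogen. Among the compounds with values here, no measured step covers this change. Compounds 2 and 3 carry a different group at that carbon and give much lower numbers than compound 1, but they also differ from compound 1 in the carbonyl chain, so the aryl change cannot be isolated. Compound 4 is therefore expected to move below compound 1 in this assay, by a 5.9-fold lower number from compound 1 to compound 4 (0.77 log units; beyond the scatter), with low confidence and a wide range: compound 4 is estimated at 2500 nM, between 300 nM and 20000 nM.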

Compound 4, half-maximal inhibitory concentration: 32900 nM
Compound 4: middle estimate off by 13-fold (1.12 log units), on the low side; the measured number lies above the stated range.
By their numbers in this assay, from the lowest: compounds 2 and 3 (each within the scatter of the next); then compound 1; then compound 4.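

In this assay, going by these compounds alone, the exchange of 3-hydroxyphenyl for 4-methoxy-3-methylphenyl on a saturated chain carbon bound to an amide-type nitrogen gives a 2.2-fold higher number from compound 1 to compound 4 (0.35 log units; beyond the scatter) and is the first step read at this place. The carbonyl chain is the same in both compounds. This is a modest change, and the exchange does not lower the number. The step swaps a hydroxyl for a methoxy and a methyl together, and nothing at hand separates these parts or accounts for the step.

As far as these compounds go, whether the far lower numbers of compounds 2 and 3 follow from their aryl group or from their carbonyl chain stays open. Also open, from the compounds shown here alone, is how an amino group in place of the hydroxyl of 3-hydroxyphenyl would read at this place.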